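Working notes on compounds 1 to 3

The source may report more compounds than this note shows. Statements on the series, on what has been measured and on what is new or still open speak of the compounds shown alone.

Measured so far:
compound 1, `COC[C@H](C)[C@@H](C)C(c1ccc(O)c(OC)c1)c1ccc(O)c(OC)c1`: 68000 nM
compound 2, `COC[C@@H](C)[C@@H](C)C(c1ccc(O)c(OC)c1)c1ccc(O)c(OC)c1`: 85000 nM

In a functional assay on HL-60 cells (Homo sapiens) for cytotoxicity, read by WST assay, with a stated time of 48 h (a lower number here means a stronger inhibitor, a higher number a weaker inhibitor), compound 1 gives 68000 nM and compound 2 gives 85000 nM. Within the data shown here, the single measured step, a 1.3-fold higher number from compound 1 to compound 2 (0.10 log units; within the scatter), rests on the fact that compounds 1 and 2 differ only in the configuration as drawn and carries nothing beyond the scatter. Compound 2 thus holds the higher of the two numbers, but its gap to compound 1 cannot be separated from repeat variation.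

Compound 3, `COc1cc(C(c2ccc(O)c(OC)c2)[C@@H](CF)C(C)C)ccc1O`, is not yet measured. It differs from compound 2 as follows: 1-(fluoromethyl)-2-methylpropyl in place of 2-(methoxymethyl)-1-methylpropyl on a saturated chain carbon bound to two aromatic carbons. Among the measured compounds shown here, this is a substituent replacement on the saturated chain carbon bound to two aromatic carbons, not a change of drawn configuration, so no measured step covers it directly. For the measured compounds named here, the only comparison available, between compound 1 and compound 2, is a configurational one and sits within the scatter. Going by the values given here, with no step bearing on the substitution itself, the expected step is a 1.1-fold lower number from compound 2 to compound 3 (0.03 log units; within the scatter), that is, none beyond the scatter. Compound 3 is estimated at 80000 nM, with a range from 30000 nM to 200000 nM.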

Compound 3, half-maximal inhibitory concentration: 39000 nM
Compound 3: middle estimate off by 2.1-fold (0.31 log units), on the high side; measured number inside the range.
By their numbers in this assay, from the lowest: compounds 3, 1 and 2 (each within the scatter of the next, the first and the last beyond it).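

Among these compounds, on the saturated chain carbon bound to two aromatic carbons, 1-(fluoromethyl)-2-methylpropyl in place of 2-(methoxymethyl)-1-methylpropyl gives the first change to move the number in this assay beyond the scatter (a 2.2-fold lower number from compound 2 to compound 3 (0.34 log units; beyond the scatter)), whereas the configurational pair showed only that the drawn configuration of one chain stereocentre had no readable effect. The same replacement read from the other configuration stays within the scatter (a 1.7-fold lower number from compound 1 to compound 3 (0.24 log units; within the scatter)), so the change is modest and its reading depends on the compound taken as reference. No measured property in the series bears on why this replacement moves the number.

Because the whole group changes in one replacement, the compounds shown do not separate the contribution of the fluoromethyl end from that of the altered branching of the chain. Also open, as far as these compounds go, is how a hydroxymethyl group, an aminomethyl group or a longer chain would read on the same saturated chain carbon, and whether any such group gives a step larger than the modest one seen here.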